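A Sulfonamide Arm Replaces Methyl on the Amide Nitrogen Aryl

The source may report more compounds than this note shows. Statements on the series, on what has been measured and on what is new or still open speak of the compounds shown alone.

Compound 1, `COc1ccc([C@H]2CC(=O)N(c3cccc(C)c3)C2)cc1OC1CCCC1`: > 10000 nM
Compound 2, `COc1ccc([C@H]2CC(=O)N(c3ccccc3C(F)(F)F)C2)cc1OC1CCCC1`: > 10000 nM
Compound 3, `COc1ccc([C@H]2CC(=O)N(c3cccnc3)C2)cc1OC1CCCC1`: > 10000 nM

In a functional assay on HEK293 cells (Homo sapiens) for cytotoxicity (a lower number here means that less compound is tolerated, a higher number that more compound is tolerated), compound 1 gives > 10000 nM, which is a limit of the assay and not a number. Compound 2 also gives only a limit, > 10000 nM. Compound 3 likewise gives only a limit, > 10000 nM. The shared picture is the limit of > 10000 nM in this assay, at which 3 of the 3 values shown sit, so the steps a step that the two limits leave unreadable from compound 1 to compound 2, a step that the two limits leave unreadable from compound 1 to compound 3 and a step that the two limits leave unreadable from compound 2 to compound 3 cannot be sized. Compound 4, `COc1ccc([C@H]2CC(=O)N(c3cccc(NS(=O)(=O)c4ccccc4F)c3)C2)cc1OC1CCCC1`, differs from compound 1 in one place: ((2-fluorophenyl)sulfonyl)amino in place of methyl on an aromatic carbon. Going by the values given here, none of the measured steps touches this position, and all three leave size and direction unreadable, so no step beyond the scatter is expected in this assay and a further limit is the likeliest outcome. Compound 4 is therefore expected at 15000 nM, with a range of 8000 nM to 40000 nM. The expected step that the limit leaves unreadable from compound 1 to compound 4 is estimated as none beyond the scatter.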

Compound 4, half-maximal cytotoxic concentration: > 10000 nM
Compound 4 gave a limit, no number (the forecaster's own chance of this, stated with the estimate: 85%); the middle value does not contradict the limit.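

No step can be read between compound 1 and compound 4, because both values are limits of the assay and not numbers: the limit of > 10000 nM in this assay, at which 4 of the 4 values shown sit.

The compounds shown leave open at what concentration any of the four turns cytotoxic in this assay, and whether the ((2-fluorophenyl)sulfonyl)amino group changes this at all.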